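The source may report more compounds than this note shows. Statements on the series, on what has been measured and on what is new or still open speak of the compounds shown alone.

Three compounds with a shared core were tested in a functional assay on PC-3 cells (Homo sapiens) for inhibition, read by MTT assay, with stated times of 18 h and 4 h; on this read-out lower numbers stand for stronger inhibition and higher numbers for weaker inhibition. Compound 2 `CCCOP(=O)(O)OCCSC(=S)N1CCCC1` gives only a limit there, > 100000 nM. Compound 1 `CCCOP(=O)(O)OCCSC(=S)N1CCCCC1` gives only a limit as well, > 100000 nM. Compound 3 `CCCCCCOP(=O)(O)OCCSC(=S)N1CCCC1` also gives only a limit, > 100000 nM. The change from compound 2 to compound 1 is piperidin-1-yl in place of pyrrolidin-1-yl on a thiocarbonyl carbon; its step that the two limits leave unreadable from compound 2 to compound 1 has no readable size because of the limit of > 100000 nM in this assay, at which 3 of the 3 values shown sit. The two cores differ by propyl in place of hydrogen on a saturated chain carbon, three bonds along the chain from an oxygen on an unsaturated carbon, and that step that the two limits leave unreadable from compound 2 to compound 3 is just as unreadable. Compound 4 `CCCCCCOP(=O)(O)OCCSC(=S)N1CCCCC1` is not yet measured; it joins the core of compound 3 with the same change, (piperidin-1-yl in place of pyrrolidin-1-yl on a thiocarbonyl carbon). Since compound 3 sits at the limit (the limit of > 100000 nM in this assay, at which 3 of the 3 values shown sit), the step of a number no higher from compound 3 to compound 4 (the limit leaves the size open) is expected to be flat. Compound 4 is therefore estimated at 100000 nM, most likely again reported only as a limit.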

Compound 4, half-maximal inhibitory concentration: > 100000 nM
Compound 4 gave a limit, no number (the forecaster's own chance of this, stated with the estimate: 85%); the middle value lies on the limit itself.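

Within the data shown here, no step to compound 4 can be read from either compound 3 or compound 1, because each value is only a limit: the limit of > 100000 nM in this assay, at which 4 of the 4 values shown sit. The compounds shown leave open whether piperidin-1-yl in place of pyrrolidin-1-yl, or the added propyl, changes inhibition at all.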